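Extending the chloro-bearing chain of compound 3

A few compounds are considered here, and "the series" means these few. Any claim that something is new, unique, unknown or untested is made for them only; others in the source may bear on it.

Measured so far in a functional assay on M21 cells (Homo sapiens) for antiproliferative activity, with a stated time of 48 h; on this read-out lower numbers stand for stronger inhibition and higher numbers for weaker inhibition:
- compound 1, `CC(C)(C)c1ccc(CNC(=O)NC(=O)CCl)cc1`, gives 2400 nM
- compound 2, `CCCCC(O)c1cccc(NC(=O)NC(=O)CCl)c1`, gives 4600 nM
- compound 3, `CCCCC(OC)c1cccc(NC(=O)CCl)c1`, gives 6900 nM

Compound 3 has the highest number of the three. Its nearest neighbour is compound 2, whose number is lower by a margin that lies within the scatter, so the two are not ordered. Compound 1 stands further off, with a number lower by a margin beyond the scatter, and it is the only one of the three with a value clearly apart from compound 3. No pair among these three differs in a single place, so no single step can be read from the measured set.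

Compound 4, `CCCCC(OC)c1cccc(NC(=O)CCCCl)c1`, is the next compound in this assay. It differs from compound 3 in one place: 2-chloroethyl in place of chloro on a saturated chain carbon bound to a carbonyl carbon. Among the measured compounds shown here, no measured compound carries a longer chain at this position, so the step has no direct precedent. The expectation is a loss rather than a gain, of a size that could exceed the scatter, with the step from compound 3 to compound 4 estimated at a 2.2-fold higher number from compound 3 to compound 4 (0.34 log units; beyond the scatter). Compound 4 is accordingly expected to give about 15000 nM, within a range from 5000 nM to 50000 nM.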

Compound 4, half-maximal inhibitory concentration: > 100000 nM
Compound 4 ended at the assay's limit; the forecaster's own chance of this, stated with the estimate: 30%; at least 6.6-fold (0.82 log units) between middle value and limit.
By their numbers in this assay, from the lowest: compounds 1, 2 and 3 (each within the scatter of the next, the first and the last beyond it). At a limit, above all of these: compound 4.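

In this assay compound 4 gives > 100000 nM, which is a limit of the assay and not a number. Among the compounds shown here, on the chain carbon bound to the carbonyl carbon, 2-chloroethyl in place of chloro gives an at least 14-fold higher number from compound 3 to compound 4 (1.16 log units; beyond the scatter), a large step beyond the scatter, so this position is far from indifferent to chain length in the one pair that can be read. All three compounds with a number in this assay carry (chloromethyl)carbonyl, while the only one with (3-chloropropyl)carbonyl sits at the limit, so the step fixes a lower bound and not a size: the limit of > 100000 nM in this assay, at which 1 of the 4 values shown sits.

Open, as far as these compounds go, is whether an intermediate chain, (2-chloroethyl)carbonyl, keeps a measurable number or already reaches the limit, and whether the chlorine matters at all, which a plain acetyl group or a bromomethyl in place of chloromethyl would address. Also open, from the compounds shown here alone, is whether the same lengthening on the cores of compound 1 and compound 2, with their urea-type linkage, gives a step of similar size.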